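The source may hold more compounds than are shown below. What is called first, only, known or untested is meant among the compounds shown, and "the series" means these compounds.

Within the data shown here, compound 3 `c1ccc2c(c1)CCC(CNCCCNc1cnccn1)O2` gives 10 nM in an assay on isolated protein (Bos taurus) with 5-hydroxytryptamine receptor 1D (Homo sapiens) as the target (on this read-out lower numbers stand for stronger inhibition and higher numbers for weaker inhibition), the highest of the three numbers measured so far. Compound 1 `c1cnc(NCCCNCC2CCc3ccccc3O2)nc1` gives 1.59 nM, and compound 2 `c1ccc2c(c1)CCC(CNCCCNC1=NCCN1)O2` gives 6.31 nM. The step of a 6.3-fold higher number from compound 1 to compound 3 (0.80 log units; beyond the scatter) and the step of a 1.6-fold higher number from compound 2 to compound 3 (0.20 log units; within the scatter) both describe swapping the group attached to that amine nitrogen, and both stayed modest or within the scatter. Compound 4 `Clc1ccc(NCCCNCC2CCc3ccccc3O2)nn1` carries 6-chloropyridazin-3-yl in place of pyrazin-2-yl on an amine nitrogen. With the two measured swaps at this position in mind, the step of a 2.0-fold lower number from compound 3 to compound 4 (0.30 log units; within the scatter) is expected to be of similar modest size, its direction uncertain, with a lower number somewhat more likely than a higher one. Compound 4 is therefore estimated at 5 nM, within a range from 1.5 nM to 20 nM.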

Compound 4, half-maximal inhibitory concentration: 2 nM
For compound 4 the middle estimate is 2.5-fold (0.40 log units) above the measured one; low and high end bracket the measured number.
By their numbers in this assay, from the lowest: compounds 1 and 4 (each within the scatter of the next); then compounds 2 and 3 (each within the scatter of the next).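

Putting 6-chloropyridazin-3-yl on the amine nitrogen gives a 5.0-fold lower number from compound 3 to compound 4 (0.70 log units; beyond the scatter) in this assay, so two rings of the same size, each with two ring nitrogens, can be told apart at this position. The new group also gives a 3.2-fold lower number from compound 2 to compound 4 (0.50 log units; beyond the scatter), whereas a 1.3-fold higher number from compound 1 to compound 4 (0.10 log units; within the scatter) leaves it level with pyrimidin-2-yl. Nothing available accounts for these steps. Still open is how much belongs to the chlorine and how much to the ring: a pyridazin-3-yl without chlorine, or one carrying methyl or methoxy instead, lies outside the compounds shown.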